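Acetyl on the ring nitrogen of compound 1

A few compounds are considered here, and "the series" means these few. Any claim that something is new, unique, unknown or untested is made for them only; others in the source may bear on it.

Compound 1 `Cc1c2c(n3c1CCNC[C@@H](C)[C@H](C)Nc1cc-3ccc1C(N)=O)CC(C)(C)CC2=O` gives 27 nM
Compound 2 `Cc1c2c(n3c1CCCN(C)[C@@H](C)[C@H](C)Nc1cc-3ccc1C(N)=O)CC(C)(C)CC2=O` gives 69 nM
Compound 3 `CC(=O)N1CCCc2c(C)c3c(n2-c2ccc(C(N)=O)c(c2)N[C@@H](C)[C@@H]1C)CC(C)(C)CC3=O` gives 20 nM

All three were measured in a functional assay on NCI-H1975 cells (Homo sapiens) for antiproliferative activity; a higher number here means a weaker inhibitor, a lower number a stronger inhibitor. On these numbers, compound 1 (27 nM) lies within the scatter of compound 3 (20 nM), while compound 2 (69 nM) reads higher than both, beyond the scatter.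

The next compound, compound 4 `CC(=O)N1CCc2c(C)c3c(n2-c2ccc(C(N)=O)c(c2)N[C@@H](C)[C@H](C)C1)CC(C)(C)CC3=O`, carries acetyl in place of hydrogen on an amine nitrogen in a ring of compound 1 (acetyl in place of hydrogen on an amine nitrogen in a ring).

Going by the values given here, one measured step bears on this change (a 3.5-fold lower number from compound 2 to compound 3 (0.54 log units; beyond the scatter)). There, acetyl takes the place of methyl on an amine nitrogen in a ring. That step is modest, but it starts from methyl rather than hydrogen, and its ring differs from that of compound 1. Among the compounds with values here, no measured pair goes from hydrogen to acetyl. Within the data shown here, compound 3, the only measured acetyl compound, gives 20 nM, close to the starting point here.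

No step beyond the scatter is therefore expected in this assay, and no direction can be favoured. The expected change is small (a 1.1-fold lower number from compound 1 to compound 4 (0.03 log units; within the scatter)). Compound 4 is estimated at 25 nM, with an expected range of 9 nM to 70 nM.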

Compound 4, half-maximal inhibitory concentration: 15 nM
Compound 4: the middle estimate sits 1.7-fold (0.22 log units) above what was measured, within the range that was stated.
By their numbers in this assay, from the lowest: compounds 4, 3 and 1 (each within the scatter of the next); then compound 2.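

Going by these compounds alone, compound 4 gives the first direct reading of hydrogen against acetyl on this amine nitrogen in a ring: in this assay the result is a 1.8-fold lower number from compound 1 to compound 4 (0.26 log units; within the scatter). The acetyl group is therefore accommodated on the ring of compound 1 without a step beyond the scatter, whereas the earlier step, a 3.5-fold lower number from compound 2 to compound 3 (0.54 log units; beyond the scatter), started from methyl on a different ring and did go beyond it. Nothing shown here accounts for this result in terms of a measured property.

As far as these compounds go, it remains open whether a longer acyl chain such as propanoyl, or a methanesulfonyl group, on this nitrogen would also stay within the scatter of compound 1. How methyl on this same nitrogen would read against hydrogen and acetyl in this ring also remains an open question.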